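The source may hold more compounds than are shown below. What is called first, only, known or untested is meant among the compounds shown, and "the series" means these compounds.

Values measured so far in a functional assay on A549 cells (Homo sapiens) for antiproliferative activity, read by MTT assay, with a stated time of 72 h; a higher number here means a weaker inhibitor, a lower number a stronger inhibitor

- Compound 1 `NC1=NC2(CCOCC2)N(OCCCOc2ccccc2)C(N)=N1` gives 1080 nM
- Compound 2 `NC1=NC2(CCSCC2)N(OCCCOc2ccc(Br)cc2)C(N)=N1` gives 740 nM
- Compound 3 `NC1=NC2(CCOCC2)N(OCCCOc2cccc(Cl)c2Cl)C(N)=N1` gives 100 nM

Compound 1 sits with compound 2 at the upper end of this small set. Their two numbers lie within the scatter of each other, while compound 3 stands well lower.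

Compound 4 `Cc1cc(C)cc(OCCCON2C(N)=NC(N)=NC23CCOCC3)c1` has not yet been measured. It differs from compound 1 in one place (3,5-dimethylphenyl in place of phenyl on an oxygen on a saturated carbon), with 3,5-dimethylphenyl in place of phenyl on an oxygen on a saturated carbon.

Within the data shown here, one measured step bears on this change at the same place (an 11-fold lower number from compound 1 to compound 3 (1.03 log units; beyond the scatter)), with 2,3-dichlorophenyl in place of phenyl. That step is large and beyond the scatter. Compound 2 differs from compound 1 in more than one place, so it offers no clean comparison. The groups added in compound 4 are methyl rather than chloro, and a single step is thin evidence. A lower number is therefore expected in this assay, but by less than that drop.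

The estimated change is a moderate one (a 3.1-fold lower number from compound 1 to compound 4 (0.49 log units; beyond the scatter)). Compound 4 is expected at 350 nM (estimated range 120 nM to 1000 nM).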

Compound 4, half-maximal inhibitory concentration: 710 nM
For compound 4 the middle estimate is 2.0-fold (0.31 log units) below the measured one; low and high end bracket the measured number.
By their numbers in this assay, from the lowest: compound 3; then compounds 4, 2 and 1 (each within the scatter of the next).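

In this assay putting 3,5-dimethylphenyl in place of phenyl gives a 1.5-fold lower number from compound 1 to compound 4 (0.18 log units; within the scatter) and so no clear change at this position. Going the other way, 3,5-dimethylphenyl in place of 2,3-dichlorophenyl gives a 7.1-fold higher number from compound 3 to compound 4 (0.85 log units; beyond the scatter) and shows that the low number of compound 3 does not come with just any pair of groups on the phenyl ring. Nothing measured here explains the difference between these two rings.

The compounds shown cannot separate the kind of group from its place on the ring, a question that 2,3-dimethylphenyl and 3,5-dichlorophenyl would speak to. Also open, as far as these compounds go, is how an amine on the phenyl ring, or a longer chain leading to that ring, would read in this assay.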